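The compounds below may be only part of what the source reports. "The series", "measured", "known", "first", "only" and "open" are said of these compounds alone.

Three compounds that share one core were tested in an ADME assay on RD cells (Homo sapiens) for cytotoxicity; on this read-out higher numbers stand for lower toxicity in this test and lower numbers for higher toxicity in this test. Compound 1 `Cc1ccccc1NC(=S)N/N=C1\C(=O)Nc2ccccc21` gives only a limit there, > 25000 nM, not a number. Compound 2 `O=C1Nc2ccccc2/C1=N/NC(=S)Nc1ccc(F)cc1` likewise reaches only the limit > 25000 nM. Compound 3 `O=C1Nc2ccccc2/C1=N/NC(=S)Nc1ccc(Cl)cc1` also stops at the limit > 25000 nM. The steps a step that the two limits leave unreadable from compound 1 to compound 2, a step that the two limits leave unreadable from compound 1 to compound 3 and a step that the two limits leave unreadable from compound 2 to compound 3 therefore cannot be read, since every value sits at the limit of > 25000 nM in this assay, at which 3 of the 3 values shown sit. Compound 4 `O=C1Nc2ccccc2/C1=N/NC(=S)Nc1ccc(Br)cc1` differs from compound 3 in a single place: bromo in place of chloro on an aromatic carbon. For the measured compounds named here, the one measured step of the same kind, fluoro to chloro, a step that the two limits leave unreadable from compound 2 to compound 3, is unreadable, so it offers no direction. Compound 4 is expected to stay at the limit too, with an estimated value of 40000 nM, ranging from 20000 nM to 100000 nM, which means an expected step that the limit leaves unreadable from compound 3 to compound 4.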

Compound 4, half-maximal cytotoxic concentration: > 25000 nM
Compound 4 was reported as a limit; the forecaster's own chance of this, stated with the estimate: 85%; the middle value is on the limit's open side.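

No step from compound 1, compound 2 or compound 3 to compound 4 can be read in this assay, since each compound gives only a limit: the limit of > 25000 nM in this assay, at which 4 of the 4 values shown sit.

On these data alone, whether these four compounds differ at all in this assay stays open.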